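The source may report more compounds than this note shows. Statements on the series, on what has been measured and on what is new or still open speak of the compounds shown alone.

Compound 1 `O=C(O)Cc1sc(C(c2ccc(F)cc2)c2ccc(F)cc2)nc1-c1ccccc1` gives 240 nM in an in vitro functional assay on HEK285-7 cells for antagonist activity at prostaglandin D2 receptor 2 (Homo sapiens), read by BRET and beta-arrestin recruitment; on this read-out lower numbers stand for stronger inhibition and higher numbers for weaker inhibition. Compound 3 `O=C(O)Cc1sc(C(c2ccc(F)cc2)c2ccc(F)cc2)nc1-c1cn[nH]c1` gives 220 nM in this assay. Compound 2 `NS(=O)(=O)c1ccc(-c2nc(C(c3ccc(F)cc3)c3ccc(F)cc3)sc2CC(=O)O)cc1` sits at a limit of this assay, > 100000 nM.

Compound 3 and compound 1 lie within the scatter of each other, with a 1.1-fold lower number from compound 1 to compound 3 (0.04 log units; within the scatter). For the measured compounds named here, compound 2 is the one case where the number is only a limit, (the limit of > 100000 nM in this assay, at which 1 of the 3 values shown sits); the step to it is an at least 410-fold higher number from compound 1 to compound 2 (2.61 log units; beyond the scatter), and back from it an at least 450-fold lower number from compound 2 to compound 3 (2.65 log units; beyond the scatter).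

Compound 4 `Cc1cc(-c2nc(C(c3ccc(F)cc3)c3ccc(F)cc3)sc2CC(=O)O)ccn1` is unmeasured. It differs from compound 3 in one place: 2-methylpyridin-4-yl in place of 1H-pyrazol-4-yl on an aromatic carbon. The measured steps that bear on this are the exchange of phenyl for 1H-pyrazol-4-yl, which left the number essentially where it was, and the addition of sulfamoyl on the phenyl, which pushed the number to the limit. A 2-methylpyridin-4-yl is a six-membered aromatic ring like the phenyl of compound 1, carrying a methyl rather than a sulfamoyl, so compound 4 is expected to sit near compound 3 with at most a modest rise, a 1.8-fold higher number from compound 3 to compound 4 (0.26 log units; within the scatter). The estimate for compound 4 in this assay is 400 nM, expected to fall between 120 nM and 2000 nM.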

Compound 4, half-maximal inhibitory concentration: 53 nM
Estimate against measurement, compound 4: 7.5-fold (0.88 log units) above; the whole stated range lies above it.
By their numbers in this assay, from the lowest: compound 4; then compounds 3 and 1 (each within the scatter of the next). At a limit, above all of these: compound 2.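

For the compounds shown here, the earlier compounds showed this position, on an aromatic carbon next to the ring nitrogen, tolerating one ring exchange without a change beyond the scatter, and the 2-methylpyridin-4-yl of compound 4 is the first group here to lower the number in this assay, with a 4.2-fold lower number from compound 3 to compound 4 (0.62 log units; beyond the scatter) and a 4.5-fold lower number from compound 1 to compound 4 (0.66 log units; beyond the scatter). The six-membered rings at this position thus span the whole measured spread, since the phenyl of compound 1 and the 2-methylpyridin-4-yl of compound 4 both outdo the substituted phenyl of compound 2 and differ from each other by a step beyond the scatter. The comparison with compound 2 rests on a limit and not on a number, and it reads an at least 1800-fold lower number from compound 2 to compound 4 (3.27 log units; beyond the scatter), so a six-membered aromatic ring alone does not fix the result at this position: the limit of > 100000 nM in this assay, at which 1 of the 4 values shown sits.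

The change from phenyl to 2-methylpyridin-4-yl brings in a ring nitrogen and a methyl together, and the compounds shown cannot separate the two, so it stays open how a plain pyridin-4-yl or a 3-methylphenyl would read. Going by these compounds, it also stays open whether a larger group in place of that methyl, such as ethyl, methoxy or an amine, would keep the lower number.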